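Swapping chloro for methyl on the outer phenoxy ring

The source may report more compounds than this note shows. Statements on the series, on what has been measured and on what is new or still open speak of the compounds shown alone.

The compounds share one core, shown in compound 1 `Cc1ccc(Oc2ccc(/C=N/n3c(C)nc4ccccc4c3=O)cc2)cc1`, compound 2 `Cc1ccc(Oc2ccc(/C=N/n3c(-c4ccccc4)nc4ccccc4c3=O)cc2)cc1` and compound 3 `CCCc1nc2ccccc2c(=O)n1/N=C/c1ccc(Oc2ccc(Cl)cc2)cc1`. In a physicochemical assay for lipophilicity, in phosphate buffer, measured as octanol-water partition (on this read-out lower numbers stand for lower lipophilicity and higher numbers for higher lipophilicity), compound 1 gives 4.32, compound 2 gives 6.29 and compound 3 gives 5.78, which places compound 3 second highest of the three, with compound 2 above it and compound 1 well below it. Among the compounds with values here, the one measured step between compounds that differ in a single place, a number 1.97 log units higher from compound 1 to compound 2 (beyond the scatter), concerns a methyl turned into a phenyl and does not touch the part of the molecule that changes next. Compound 4 `CCCc1nc2ccccc2c(=O)n1/N=C/c1ccc(Oc2ccc(C)cc2)cc1` arises from compound 3 by methyl in place of chloro on an aromatic carbon. Compound 1 and compound 3 differ in two places at once, so their values alone cannot be tied to this swap. Within the data shown here, with no measured step of this kind to lean on, only a small shift, if any, is expected in this assay for compound 4, within the scatter of the method, as a number 0.15 log units lower from compound 3 to compound 4 (within the scatter). Compound 4 is therefore estimated at 5.63, with a likely range from 5.2 to 6.1.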

Compound 4, partition coefficient: 5.45
For compound 4 the middle estimate is 0.18 log units above the measured one, and the stated range covers the measured number.
By their numbers in this assay, from the lowest: compound 1; then compound 4; then compound 3; then compound 2.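

In this assay, the change from 4-chlorophenoxy to 4-methylphenoxy now has a measured size, with a number 0.33 log units lower from compound 3 to compound 4 (beyond the scatter) as a modest step and the first one read at this position. With methyl held on the outer ring, compound 4 also gives the group on the shared core two further readings: methyl becoming propyl brings a number 1.13 log units higher from compound 1 to compound 4 (beyond the scatter) as a large step, and phenyl becoming propyl brings a number 0.84 log units lower from compound 2 to compound 4 (beyond the scatter) as a modest one. Both of these steps are larger than the outer-ring swap, so among these compounds the group on the core moves the number further.

No measurement shown explains the size of any of these steps. Going by these compounds, the outer-ring swap is also read only with propyl on the core, so it remains open how it behaves with methyl or phenyl there, and where a methoxy group or a fluorine on the outer ring would fall.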